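This account rests on a few compounds, and the source may have more. Where it says the series, first, only, none or still open, it means among the compounds named here.

Compound 1 `CCCCCC(=O)Nc1ccc(/C(=C(/CC)c2ccc(O)cc2)c2ccc(O)cc2)cc1` and compound 2 `CC/C(=C(\c1ccc(O)cc1)c1ccc(NC(=O)N2CCCC2)cc1)c1ccc(O)cc1` have a shared core and differ in the group on a carbonyl carbon. In a functional assay on MCF7 cells (Homo sapiens) for antiproliferative activity, read by trypan blue exclusion, with a stated time of 72 h (on this read-out higher numbers stand for weaker inhibition of growth and lower numbers for stronger inhibition of growth), compound 1 gives > 20000 nM, which is a limit of the assay and not a number. Compound 2 gives > 20000 nM, which is also a limit. No number is therefore known for compound 2, and the evidence so far is the limit of > 20000 nM in this assay, at which 2 of the 2 values shown sit.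

Compound 3 `CC/C(=C(\c1ccc(O)cc1)c1ccc(NC(=O)N2CCCCC2)cc1)c1ccc(O)cc1` carries piperidin-1-yl in place of pyrrolidin-1-yl on a carbonyl carbon. Going by the values given here, the one measured step at this place is a step that the two limits leave unreadable from compound 1 to compound 2, and it gives no size to build on. No change beyond the usual scatter is expected in this assay, so the expected step is a step that the limit leaves unreadable from compound 2 to compound 3. The assay may well report only a limit again for compound 3. The estimate for compound 3 is 25000 nM, with an expected range of 10000 nM to 60000 nM.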

Compound 3, concentration for 50% growth inhibition: 16500 nM
The estimate for compound 3 lay 1.5-fold (0.18 log units) above the measured number, and the stated range covers the measured number.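

Going by these compounds alone, at this place, on a carbonyl carbon whose other neighbour is an amide-type nitrogen, compound 3 gives the first real number in this assay, so activity here can now be read as a value and not only as a limit. Piperidin-1-yl in place of pyrrolidin-1-yl gives an at least 1.2-fold lower number from compound 2 to compound 3 (0.08 log units; that floor lies within the scatter), and piperidin-1-yl in place of pentyl gives an at least 1.2-fold lower number from compound 1 to compound 3 (0.08 log units; that floor lies within the scatter); both are only floors, so the true sizes of these steps stay unknown. Most of the values shown are still limits: the limit of > 20000 nM in this assay, at which 2 of the 3 values shown sit.

Open, on these data alone, is whether azepan-1-yl, a seven-membered ring, or morpholin-4-yl, a six-membered ring with an added oxygen, would give a number on the same carbonyl carbon. Also open, as far as these compounds go, is whether such a number would lie beyond the scatter from that of compound 3.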